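Indole-oxazole series: methylation of the indole nitrogen

A few compounds are considered here, and "the series" means these few. Any claim that something is new, unique, unknown or untested is made for them only; others in the source may bear on it.

Among the measured compounds shown here, compound 2 `c1ccc2c(-c3coc(C4CCNCC4)n3)c[nH]c2c1` stands at the higher end of the two values measured so far in a functional assay on DU-145 cells (Homo sapiens) for cytotoxicity, read by MTT assay, with a stated time of 48 h; a lower number here means a stronger inhibitor, a higher number a weaker inhibitor: compound 2 gives 381000 nM, while compound 1 `c1ccc(-c2nc(-c3c[nH]c4ccccc34)co2)cc1` gives 167000 nM. For the measured compounds named here, the one step on record, a 2.3-fold higher number from compound 1 to compound 2 (0.36 log units; beyond the scatter), concerns the piperidin-4-yl for phenyl exchange and does not touch the indole nitrogen.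

Compound 3 `Cn1cc(-c2coc(C3CCNCC3)n2)c2ccccc21` differs from compound 2 only by methyl in place of hydrogen on an aromatic nitrogen. Going by the values given here, no measured step bears on this change; the series offers no precedent for capping the indole nitrogen, so the direction of the step is open. Among the compounds with values here, the only step seen so far, a 2.3-fold higher number from compound 1 to compound 2 (0.36 log units; beyond the scatter), was modest, which gives no reason to expect a large move here. The expected step is a 1.0-fold higher number from compound 2 to compound 3 (0.02 log units; within the scatter), within the usual scatter. For compound 3 the estimate in this assay is 400000 nM, with a range from 150000 nM to 1000000 nM.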

Compound 3, half-maximal inhibitory concentration: 376000 nM
For compound 3 the middle estimate is 1.1-fold (0.03 log units) above the measured one; the range from low to high includes it.
By their numbers in this assay, from the lowest: compound 1; then compounds 3 and 2 (each within the scatter of the next).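

In this assay, methyl in place of hydrogen on the aromatic nitrogen gives a 1.0-fold lower number from compound 2 to compound 3 (0.01 log units; within the scatter), so compound 2 and compound 3 cannot be told apart. Among the compounds shown here, this is the first reading at this position, and for this pair, with piperidin-4-yl as the large group's partner on the core, capping the nitrogen with a single carbon costs nothing measurable and gains nothing measurable. Nothing available accounts for this result, and it rests on one pair of compounds.

As far as these compounds go, whether methyl on this nitrogen would read the same alongside phenyl, the group carried by compound 1, remains open. Also open, from the compounds shown here alone, is whether a larger group on the same nitrogen, such as a longer chain like n-butyl or a benzyl group, would move the number beyond the scatter.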